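A few compounds are considered here, and "the series" means these few. Any claim that something is new, unique, unknown or untested is made for them only; others in the source may bear on it.

Compound 1 `COc1cc(-c2nc(SCc3cn(CC(=O)NC(=O)Nc4ccccn4)nn3)nc(Nc3cccc(C(F)(F)F)c3)c2C#N)cc(OC)c1OC` in a functional assay on ECa-109 cells (Homo sapiens) for inhibition, read by MTT assay, with a stated time of 72 h; a lower number here means a stronger inhibitor, a higher number a weaker inhibitor: > 64000 nM.
Compound 2 `COc1cc(-c2nc(SCc3cn(CC(=O)NC(=O)Nc4ccccn4)nn3)nc(Nc3ccc(Cl)cc3)c2C#N)cc(OC)c1OC`: > 64000 nM.
Compound 3 `COc1cc(-c2nc(SCc3cn(CC(=O)NC(=O)Nc4ccccn4)nn3)nc(Nc3cccc(Cl)c3)c2C#N)cc(OC)c1OC`: > 64000 nM.

Each of these three values is a limit of this assay, not a measured number, and compound 3 therefore stands at the same limit as the other two, as the limit of > 64000 nM in this assay, at which 3 of the 3 values shown sit, shows. The steps among them, a step that the two limits leave unreadable from compound 1 to compound 2, a step that the two limits leave unreadable from compound 1 to compound 3 and a step that the two limits leave unreadable from compound 2 to compound 3, all change the aniline side and none can be sized. Compound 4 `Cc1ccc(-c2nc(SCc3cn(CC(=O)NC(=O)Nc4ccccn4)nn3)nc(Nc3cccc(Cl)c3)c2C#N)cc1` differs from compound 3 elsewhere: 4-methylphenyl in place of 3,4,5-trimethoxyphenyl on an aromatic carbon. Among the compounds with values here, no measured step touches that position, so nothing points to a gain in potency. Compound 4 is expected to give 80000 nM, between 20000 nM and 300000 nM. The step from compound 3 to compound 4 is thus estimated as a step that the limit leaves unreadable from compound 3 to compound 4.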

Compound 4, half-maximal inhibitory concentration: 25600 nM
For compound 4 the middle estimate is 3.1-fold (0.49 log units) above the measured one, and the stated range covers the measured number.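

The aryl group on this carbon, opposite the ring nitrogen, can shift the result in this assay: 4-methylphenyl in place of 3,4,5-trimethoxyphenyl gives an at least 2.5-fold lower number from compound 3 to compound 4 (0.39 log units; beyond the scatter). Compound 4 is thus the only compound shown with a real number. The steps among compound 1, compound 2 and compound 3 cannot be read, and this new step gives only a minimum size, because the value of compound 3 is a limit, not a number: the limit of > 64000 nM in this assay, at which 3 of the 4 values shown sit.

As far as these compounds go, it remains open whether removing the methoxy groups or adding the methyl matters more. From the compounds shown here alone, how an unsubstituted phenyl, or a phenyl carrying an amine or a carboxylic acid, would behave here also remains open.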